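Dropping the methoxy: what to expect for compound 4

This account rests on a few compounds, and the source may have more. Where it says the series, first, only, none or still open, it means among the compounds named here.

Of the compounds shown here, three built on one shared core have been measured in an ADME assay on MT4 cells (Homo sapiens) for cytotoxicity, read by MTT assay, with a stated time of 4 days; a lower number here means that less compound is tolerated, a higher number that more compound is tolerated. Compound 1 `COc1ccc(-c2cc(C)c(Nc3ccnc(Nc4ccc(C#N)cc4)n3)c(C)c2)cc1` gives 2890 nM. Compound 2 `Cc1cc(-c2ccc(F)cc2)cc(C)c1Nc1ccnc(Nc2ccc(C#N)cc2)n1` gives 4170 nM. Compound 3 `COc1ccccc1-c1cc(C)c(Nc2ccnc(Nc3ccc(C#N)cc3)n2)c(C)c1` gives 940 nM, the lowest of the three numbers, so it is the least well tolerated of the set. The step of a 3.1-fold lower number from compound 1 to compound 3 (0.49 log units; beyond the scatter) and the step of a 4.4-fold lower number from compound 2 to compound 3 (0.65 log units; beyond the scatter) both lie beyond the scatter, whereas the step of a 1.4-fold higher number from compound 1 to compound 2 (0.16 log units; within the scatter) does not. Compound 4 `Cc1cc(-c2ccccc2)cc(C)c1Nc1ccnc(Nc2ccc(C#N)cc2)n1` differs from compound 3 by hydrogen in place of methoxy on an aromatic carbon. Going by the values given here, no measured pair shows exactly this change; the two steps that bear on it show that the 2-methoxyphenyl arrangement goes with a clearly lower number than either 4-methoxyphenyl or 4-fluorophenyl. Taking the methoxy away altogether is expected to move the number toward those of compound 1 and compound 2, so for compound 4 a modest rise, expected as a 2.1-fold higher number from compound 3 to compound 4 (0.33 log units; beyond the scatter), seems likely. Compound 4 is therefore estimated at 2000 nM, with a range from 800 nM to 5000 nM.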

Compound 4, half-maximal cytotoxic concentration: 4170 nM
For compound 4 the middle estimate is 2.1-fold (0.32 log units) below the measured one; low and high end bracket the measured number.
By their numbers in this assay, from the lowest: compound 3; then compounds 1, 2 and 4 (each within the scatter of the next).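

The step of a 4.4-fold higher number from compound 3 to compound 4 (0.65 log units; beyond the scatter) in this assay reads this change directly: once the methoxy ortho to a large group is gone, the low number does not persist. The plain phenyl group cannot be told apart from the other two groups, with readings of no change at the digits printed from compound 2 to compound 4 (within the scatter) and a 1.4-fold higher number from compound 1 to compound 4 (0.16 log units; within the scatter). Among these four compounds, therefore, the lower number goes with the 2-methoxyphenyl group of compound 3, and a methoxy as such does not guarantee it, as compound 1 with its 4-methoxyphenyl group shows.

Going by these compounds, whether an amine, a hydroxyl group or a longer chain such as ethoxy at this same place would also go with a low number stays open. Nothing measured here explains why the methoxy matters at this place.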